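From cyclopentylsulfanyl to butoxy on the shared core

The source may report more compounds than this note shows. Statements on the series, on what has been measured and on what is new or still open speak of the compounds shown alone.

In an ADME assay on BCBL1 cells (Homo sapiens) for cytotoxicity, with a stated time of 7 days (on this read-out higher numbers stand for lower toxicity in this test and lower numbers for higher toxicity in this test), compound 1 `Nc1nc(NC2CC2)c2ncn(/C=C3/CC3(CO)CO)c2n1` gives 71500 nM. Compound 2 `Nc1nc(SC2CCCC2)c2ncn(/C=C3/CC3(CO)CO)c2n1` is reported only as a limit, > 20000 nM, and not as a number. That leaves the limit of > 20000 nM in this assay, at which 1 of the 2 values shown sits, as all that can be said of its standing.

Compound 3 `CCCCOc1nc(N)nc2c1ncn2/C=C1/CC1(CO)CO` keeps the core and changes one group: butoxy in place of cyclopentylsulfanyl on an aromatic carbon. Butoxy replaces cyclopentylsulfanyl on the same aromatic carbon, so the five-membered non-aromatic ring of carbon only leaves and no ring enters.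

For the measured compounds named here, the only measured step is a step that the limit leaves unreadable from compound 1 to compound 2. It sets no size to carry over, and it gives no direction for the change to butoxy. Going by the values given here, no step beyond the scatter can be argued in this assay, so the expectation rests on the one true number, compound 1 at 71500 nM. The expectation also rests on the limit of compound 2. The expected change is a step that the limit leaves unreadable from compound 2 to compound 3, and it is a loose estimate measured against a limit. Compound 3 is expected at 40000 nM, within an estimated range of 12000 nM to 100000 nM.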

Compound 3, half-maximal cytotoxic concentration: > 20000 nM
Compound 3 was reported as a limit; the forecaster's own chance of this, stated with the estimate: 50%; the middle value is on the limit's open side.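

In this assay compound 3 is reported only as a limit, > 20000 nM, and not as a number. No step can be read from compound 2 to compound 3 or from compound 1 to compound 3. Still open is where compound 2 and compound 3 stand relative to compound 1 and to each other, as all that is available for them is: the limit of > 20000 nM in this assay, at which 2 of the 3 values shown sit.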